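The source may report more compounds than this note shows. Statements on the series, on what has been measured and on what is new or still open speak of the compounds shown alone.

In an assay (Populus sieboldii x Populus grandidentata) for inhibition of Trans-cinnamate 4-monooxygenase (Populus kitakamiensis), with a stated time of 60 min (on this read-out lower numbers stand for stronger inhibition and higher numbers for weaker inhibition), three compounds of a shared core have been measured so far. Compound 1, with the structure `c1ccc(-c2nnco2)cc1`, gives only a limit, > 100000 nM, which is the edge of what the assay can report rather than a number (the limit of > 100000 nM in this assay, at which 1 of the 3 values shown sits). Compound 2, with the structure `Cc1cccc(-c2nnc(S)o2)c1`, gives 1100 nM in this assay. Compound 3, with the structure `Cc1ccc(-c2nnc(S)o2)cc1`, gives 50000 nM in this assay, the higher of the two numbers shown; the gap between compound 2 and compound 3 lies beyond the usual scatter of repeated measurements, so compound 3 is the weaker inhibitor of the two.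

The next compound, compound 4, with the structure `Fc1ccc(-c2nnc(S)o2)cc1`, differs from compound 3 in a single place: fluoro in place of methyl on an aromatic carbon. Going by the values given here, no pair of measured compounds shows the effect of this change, so the expectation rests on the structures alone. Both groups are small and neither adds a hydrogen-bond donor or acceptor, so the step from compound 3 to compound 4 is expected to be modest, a 1.3-fold lower number from compound 3 to compound 4 (0.10 log units; within the scatter), and possibly no larger than the scatter. Compound 4 is therefore estimated to give 40000 nM in this assay, with a plausible range from 8000 nM to 150000 nM.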

Compound 4, half-maximal inhibitory concentration: 3300 nM
The estimate for compound 4 lay 12-fold (1.08 log units) above the measured number, and the stated range ends above it.
By their numbers in this assay, from the lowest: compound 2; then compound 4; then compound 3. At a limit, above all of these: compound 1.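

Swapping methyl for fluoro on this aromatic carbon in this assay gives a 15-fold lower number from compound 3 to compound 4 (1.18 log units; beyond the scatter) and this step lies beyond the scatter, even though both groups have the same heavy-atom count and neither has a hydrogen-bond donor or acceptor. Going by these compounds alone, no earlier pair of compounds had tested a change at this position, so this is the first sign that inhibition here can depend strongly on which small group sits para to the group of 6 heavy atoms. Nothing measured among these compounds accounts for the size of this step.

The compounds shown leave open how other groups on this same carbon, such as chloro, hydroxyl or an amine, would compare, and so whether fluoro is a special case or one point in a broader pattern. They also leave open whether the same swap of methyl for fluoro would give a step of similar size on another carbon of the six-membered ring.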